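A bromo in place of a methyl

The compounds below may be only part of what the source reports. "The series", "measured", "known", "first", "only" and "open" are said of these compounds alone.

In a functional assay on HeLa cells (Homo sapiens) for inhibition, read by CCK-8 assay, with a stated time of 72 h, tested at 2 uM (a higher number here means more inhibition of growth at the concentration tested, a lower number less inhibition of growth), compound 3 (`Cc1ccc(SCc2ccc(C(=O)Nc3ccccc3N)cc2)cc1`) gives 33.8%. Compound 1 (`COc1ccc(SCc2ccc(C(=O)Nc3ccccc3N)cc2)cc1`) lies within the scatter of that number at 35%. Compound 2 (`Nc1ccccc1NC(=O)c1ccc(CSc2cccc(F)c2)cc1`) gives the lowest number of the three, 22.5%.

Compound 4 (`Nc1ccccc1NC(=O)c1ccc(CSc2ccc(Br)cc2)cc1`) has bromo in place of methyl on an aromatic carbon. For the measured compounds named here, no measured pair makes this exact change. The step of a number 1.2 percentage points lower from compound 1 to compound 3 (within the scatter) shows one swap at this place with no change beyond the scatter. Going by the values given here, the only halogen-bearing example is the 3-fluorophenyl of compound 2, seen in a number 11.3 percentage points higher from compound 2 to compound 3 (beyond the scatter) and a number 12.5 percentage points lower from compound 1 to compound 2 (beyond the scatter), and its halogen sits elsewhere. A small downward shift within the scatter is therefore expected, an estimated a number 4.8 percentage points lower from compound 3 to compound 4 (within the scatter). Compound 4 is expected at 29%, with an estimated range of 18% to 41%.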

Compound 4, percent growth inhibition at one concentration: 18.8%
Estimate against measurement, compound 4: 10.2 percentage points above; the range from low to high includes it.
By their numbers in this assay, from the lowest: compounds 4 and 2 (each within the scatter of the next); then compounds 3 and 1 (each within the scatter of the next).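

In this assay, for the compounds shown here, bromo in place of methyl is the first swap at this aromatic carbon to move the number beyond the scatter (a number 15 percentage points lower from compound 3 to compound 4 (beyond the scatter)), and bromo in place of methoxy does the same (a number 16.2 percentage points lower from compound 1 to compound 4 (beyond the scatter)). The 4-bromophenyl and the 3-fluorophenyl stay close together (a number 3.7 percentage points lower from compound 2 to compound 4 (within the scatter)), so both halogen-bearing compounds sit low among these four. Nothing measured here gives a reason for this shift.
As far as these compounds go, what a chloro or an amine would give at this aromatic carbon stays open. So does whether a fluoro here would match bromo.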